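This account rests on a few compounds, and the source may have more. Where it says the series, first, only, none or still open, it means among the compounds named here.

Measured compounds:
Compound 1, `CCC(CC)Cn1c(Cc2cc(OC)c(OC)c(OC)c2)nc2c(N)ncnc21`, gives 158000 nM.
Compound 2, `C#CCCn1c(Cc2cc(OC)c(OC)c(OC)c2)nc2c(N)nc(F)nc21`, gives 25100 nM.

In a functional assay on MCF7 cells (Homo sapiens) for antiproliferative activity (a higher number here means a weaker inhibitor, a lower number a stronger inhibitor), compound 1 stands as the weaker of the two, with the higher number; the gap to compound 2 is beyond the scatter. Compound 3, `CCCn1c(Cc2cc(OC)c(OC)c(OC)c2)nc2c(N)ncnc21`, is not yet measured. It differs from compound 1 in one place: ethyl in place of pentan-3-yl on a saturated chain carbon bound to an aromatic nitrogen. Among the measured compounds shown here, no measured pair shows what this kind of change does, so the direction is open. The expected step is a 1.3-fold lower number from compound 1 to compound 3 (0.12 log units; within the scatter). Compound 3 is therefore estimated at 120000 nM, with a range from 30000 nM to 400000 nM.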

Compound 3, half-maximal inhibitory concentration: 46800 nM
The estimate for compound 3 lay 2.6-fold (0.41 log units) above the measured number; the range from low to high includes it.
By their numbers in this assay, from the lowest: compounds 2 and 3 (each within the scatter of the next); then compound 1.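

In this assay, the group on a saturated chain carbon bound to an aromatic nitrogen proves able to shift the number: ethyl in place of pentan-3-yl gives a 3.4-fold lower number from compound 1 to compound 3 (0.53 log units; beyond the scatter). Among the compounds shown here, this modest step is the first reading of a single change at this position, and here the smaller group goes with the lower number, in this one pair only. Nothing available explains the step.

Going by these compounds, whether a hydroxyl or an amine on this chain, or a cyclohexyl group in its place, would lower the number further remains open. It is also unknown whether the same change would give a similar step on the fluorine-bearing core of compound 2.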